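Taking the phenyl back off a thiophene amine

The source may hold more compounds than are shown below. What is called first, only, known or untested is meant among the compounds shown, and "the series" means these compounds.

Of the compounds shown here, three built on a shared core have been measured in an ADME assay on MDCK cells (Canis lupus familiaris) for cytotoxicity, read by microscopy, with a stated time of 48 h; on this read-out lower numbers stand for higher toxicity in this test and higher numbers for lower toxicity in this test. Compound 1 `C[C@H]1[C@H](NCc2ccsc2)C[C@H]2C[C@@H]1C2(C)C` gives 50000 nM. Compound 2 `C=Cc1ccsc1CN[C@@H]1C[C@H]2C[C@@H]([C@H]1C)C2(C)C`, which carries a vinyl group on its five-membered ring, gives 50000 nM. Compound 3 `C[C@H]1[C@H](NCc2sccc2-c2ccccc2)C[C@H]2C[C@@H]1C2(C)C` gives 12500 nM, the lowest of the three numbers and so the most toxic compound of this set; its distance to compound 1 and to compound 2 lies beyond the scatter in both cases. Going by the values given here, the only step in which a single place differs is a 4.0-fold lower number from compound 2 to compound 3 (0.60 log units; beyond the scatter).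

Compound 4 `C[C@H]1[C@H](NCc2cccs2)C[C@H]2C[C@@H]1C2(C)C` differs from compound 3 in one place: hydrogen in place of phenyl on an aromatic carbon. The step from compound 2 to compound 3 bears directly on this change. It introduced the very same phenyl group and gave a modest but clear lowering of the number. Removing that phenyl again should undo this, so a step of similar size in the opposite direction is expected, bringing the number back toward those of compound 1 and compound 2, both of which lack a phenyl. Compound 4 is therefore estimated to give 50000 nM, within a range from 25000 nM to 100000 nM, which corresponds to an expected step of a 4.0-fold higher number from compound 3 to compound 4 (0.60 log units; beyond the scatter).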

Compound 4, minimum cytotoxic concentration: 25000 nM
Beside the measured number, compound 4's estimate is 2.0-fold (0.30 log units) above it, within the range that was stated.
By their numbers in this assay, from the lowest: compounds 3, 4, 1 and 2 (each within the scatter of the next, the first and the last beyond it).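

In this assay, removing the phenyl gives a 2.0-fold higher number from compound 3 to compound 4 (0.30 log units; within the scatter) and so does not produce a change that can be told apart from the usual scatter, whereas the earlier step of a 4.0-fold lower number from compound 2 to compound 3 (0.60 log units; beyond the scatter) lay beyond it. Compound 4, with only hydrogen at this aromatic carbon, also stays within the scatter of both phenyl-free comparison compounds: hydrogen in place of vinyl gives a 2.0-fold lower number from compound 2 to compound 4 (0.30 log units; within the scatter) and thiophen-2-yl in place of thiophen-3-yl gives a 2.0-fold lower number from compound 1 to compound 4 (0.30 log units; within the scatter) as a separate change at the saturated chain carbon bound to the amine nitrogen. The compounds thus give no firm sign that phenyl at this place matters on its own, and no supporting data say what lies behind these small differences.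

From the compounds shown here alone, it remains open whether a smaller group such as methyl, or a group such as an amine or a carboxylic acid, on the same aromatic carbon would move the number beyond the scatter. Also open, going by these compounds, is whether a larger ring system or a longer chain there would give a clearer step than phenyl does.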